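Swapping methoxy for ethyl on a fused aromatic core

The source may report more compounds than this note shows. Statements on the series, on what has been measured and on what is new or still open speak of the compounds shown alone.

Measured compounds:
Compound 1, `CCc1cc(C)cc2nc(N3CCN(C)CC3)oc12`: 0.26
Compound 2, `COc1cc(Cl)cc2nc(N3CCN(C)CC3)oc12`: 0.62
Compound 3, `COc1cc(C)cc2nc(N3CCN(C)CC3)oc12`: 0.56

All three compounds were tested in an assay on ileum (strain Hartley) with 5-hydroxytryptamine receptor 3A (Cavia porcellus) as the target; a lower number here means a smaller maximal response, a higher number a larger maximal response. Compound 2 gives the largest of the three numbers, yet the step a number 0.060 lower from compound 2 to compound 3 (within the scatter) is within the scatter, so compound 2 and compound 3 cannot be told apart; only compound 1 sits clearly lower.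

Compound 4, `CCc1cc(Cl)cc2nc(N3CCN(C)CC3)oc12`, has not yet been measured. It differs from compound 2 in one place: ethyl in place of methoxy on an aromatic carbon.

One measured step speaks directly to this change, in the reverse direction: a number 0.30 higher from compound 1 to compound 3 (beyond the scatter). There, methoxy entering in place of ethyl raised the maximal response by a modest but clear amount. Going the other way, from methoxy to ethyl, a drop of about the same size is therefore expected in this assay. Compound 2 and compound 3 show that chloro against methyl in the other position barely matters, so the drop seen between compound 1 and compound 3 is expected to carry over to the chloro series.

For compound 4 the estimate is 0.32, ranging from 0.15 to 0.5, an expected step of a number 0.30 lower from compound 2 to compound 4 (beyond the scatter).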

Compound 4, intrinsic activity: the largest response reached, as a fraction of the reference agonist's: 0.17
Compound 4: the middle estimate sits 0.15 above what was measured; the measured number falls inside the stated range.
By their numbers in this assay, from the lowest: compounds 4 and 1 (each within the scatter of the next); then compounds 3 and 2 (each within the scatter of the next).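

Ethyl in place of methoxy on the chloro-bearing core gives a number 0.45 lower from compound 2 to compound 4 (beyond the scatter), so the fall in maximal response seen on the methyl-bearing core is not confined to that core. In this assay the change keeps its direction on both cores, but its size does not carry over unchanged, and a single step would not have revealed this: the same change on two cores in this assay, a number 0.30 higher (beyond the scatter) from compound 1 to compound 3 and a number 0.45 higher (beyond the scatter) from compound 4 to compound 2, 0.15 apart, beyond the scatter of two such steps

Chloro in place of methyl on the ethyl-bearing core gives a number 0.090 lower from compound 1 to compound 4 (within the scatter), so this swap cannot be told from scatter on either core when read alone, yet the two steps taken together do differ, which shows that the two positions are not fully independent of each other: the same change on two cores in this assay, a number 0.060 lower (within the scatter) from compound 2 to compound 3 and a number 0.090 higher (within the scatter) from compound 4 to compound 1, 0.15 apart, beyond the scatter of two such steps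

The compounds shown carry only methoxy and ethyl at this position, so how a hydroxyl, an amine or a longer chain such as propoxy would fare there remains open. On these data alone, it also remains open whether the size of the methoxy-to-ethyl step would shift again with fluoro or a nitrile in place of the chloro group.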